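Methyl to Ethyl on the Aniline Side of a Urea

A few compounds are considered here, and "the series" means these few. Any claim that something is new, unique, unknown or untested is made for them only; others in the source may bear on it.

Two ureas have been measured in an ADME assay on the whole organism with Oryza sativa as the target, tested at 1 uM; a higher number here means a weaker effect of the compound at the concentration tested, a lower number a stronger effect. Compound 1, `Cc1ccccc1NC(=O)N[C@@H](C)c1ccccc1`, gives 99%. Compound 2, `Cc1cccc(NC(=O)N[C@@H](C)c2ccccc2)c1`, gives 100%, the higher of the two numbers, though its distance to compound 1 lies within the scatter, so no order can be read from them. Compound 3, `CCc1cccc(NC(=O)N[C@@H](C)c2ccccc2)c1`, has not yet been measured; it differs from compound 2 by methyl in place of hydrogen on a saturated chain carbon bound to an aromatic carbon. Among the measured compounds shown here, with only two near-identical values to go on, no step beyond the scatter is expected in this assay, so the estimate from compound 2 to compound 3 is a number 1 percentage points lower from compound 2 to compound 3 (within the scatter). Compound 3 is therefore expected to give about 99%, within 93% to 100%.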

Compound 3, a percentage reported as activity, at one concentration (the size of the read-out at that concentration, not a potency): 94%
Compound 3: middle estimate off by 5 percentage points, on the high side; the range from low to high includes it.
By their numbers in this assay, from the lowest: compounds 3, 1 and 2 (each within the scatter of the next).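

In this assay the change of methyl to ethyl, on a saturated chain carbon bound to an aromatic carbon, gives a number 6 percentage points lower from compound 2 to compound 3 (within the scatter) and so cannot be told apart from repeat measurements. Among the compounds shown here, this is the first single-place step available, and it shows that one added methyl at this position produces no readable effect on the compound. No independent measurement bears on this result.

On these data alone, whether a longer chain such as propyl, or an amine or a carboxylic acid at this place, would move the number beyond the scatter remains open.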